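Trimming the Alkyne Chain to a Hydroxymethyl Terminus

The source may report more compounds than this note shows. Statements on the series, on what has been measured and on what is new or still open speak of the compounds shown alone.

Measured in an assay on a protein complex for binding affinity to Neuronal acetylcholine receptor; alpha3/beta2 (Homo sapiens); a higher number here means a weaker inhibitor, a lower number a stronger inhibitor:
compound 1 `CN1CCC[C@H]1COc1cccnc1` — 7.7 nM
compound 2 `CN1CCC[C@H]1COc1cncc(C#CCCCCF)c1` — 14 nM
compound 3 `CCCCC#Cc1cncc(OC[C@@H]2CCCN2C)c1` — 21 nM

Compound 3 stands at the highest of the three numbers. Its nearest neighbour is compound 2, where a 1.5-fold higher number from compound 2 to compound 3 (0.18 log units; within the scatter) lies within the scatter, while against compound 1 the step of a 2.7-fold higher number from compound 1 to compound 3 (0.44 log units; beyond the scatter) is a modest loss beyond it. Compound 4 `CN1CCC[C@H]1COc1cncc(C#CCO)c1` differs from compound 3 by hydroxy in place of propyl on a saturated chain carbon bound to a triple-bonded carbon. Within the data shown here, no measured pair exchanges chain carbons for a hydroxy group, so the evidence is indirect. The steps of a 1.8-fold higher number from compound 1 to compound 2 (0.26 log units; within the scatter) and a 1.5-fold higher number from compound 2 to compound 3 (0.18 log units; within the scatter) show that the far end of the alkyne chain, fluorine present or absent, shifts the number little, and a 2.7-fold higher number from compound 1 to compound 3 (0.44 log units; beyond the scatter) shows that the whole chain costs only modestly. Compound 4 is therefore expected to show a 1.4-fold lower number from compound 3 to compound 4 (0.15 log units; within the scatter), that is, no step beyond the scatter in this assay. Compound 4 is estimated at 15 nM, with a range from 5 nM to 45 nM.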

Compound 4, inhibition constant: 7.1 nM
Compound 4: middle estimate off by 2.1-fold (0.32 log units), on the high side, and the stated range covers the measured number.
By their numbers in this assay, from the lowest: compounds 4, 1, 2 and 3 (each within the scatter of the next, the first and the last beyond it).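

In this assay, among these compounds, a 3.0-fold lower number from compound 3 to compound 4 (0.47 log units; beyond the scatter) is the first step at this position beyond the scatter towards a lower number, and it comes with hydroxy in place of propyl on the saturated chain carbon bound to a triple-bonded carbon. The 3-hydroxyprop-1-yn-1-yl group stays within the scatter of both the unsubstituted core (a 1.1-fold lower number from compound 1 to compound 4 (0.04 log units; within the scatter)) and the fluorinated chain (a 2.0-fold lower number from compound 2 to compound 4 (0.29 log units; within the scatter)), so among these chains only hex-1-yn-1-yl is separated from hydrogen on the aromatic carbon by a step beyond the scatter. Nothing shown gives a measured reason for this result.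

The compounds shown leave open whether the step belongs to the hydroxy group or to the shortening of the chain. A but-1-yn-1-yl chain, with a plain methyl end, and a 6-hydroxyhex-1-yn-1-yl chain would pull those two changes apart.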